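This account rests on a few compounds, and the source may have more. Where it says the series, first, only, none or still open, it means among the compounds named here.

In a functional assay on HepG2 cells (Homo sapiens) for cytotoxicity, read by MTT assay, with a stated time of 48 h (on this read-out lower numbers stand for stronger inhibition and higher numbers for weaker inhibition), compound 1 `COc1ccc(-c2nnc(SCCn3c([N+](=O)[O-])cnc3C)o2)cc1` gives 5800 nM. This is within the scatter of compound 2 `CCOc1ccccc1-c1nnc(SCCn2c([N+](=O)[O-])cnc2C)o1` at 9800 nM, while compound 3 `Cc1ncc([N+](=O)[O-])n1CCSc1nnc(-c2ccccc2[N+](=O)[O-])o1` lies clearly lower at 700 nM. Compound 4 `Cc1ncc([N+](=O)[O-])n1CCSc1nnc(-c2ccc(F)cc2)o1` departs from compound 1 by fluoro in place of methoxy on an aromatic carbon, that is, 4-methoxyphenyl to 4-fluorophenyl. Among the measured compounds shown here, the only measured step that bears on this is the large 14-fold lower number from compound 2 to compound 3 (1.15 log units; beyond the scatter), where nitro replaces ethoxy on an aromatic carbon. That step involves different groups, so it gives only loose guidance, and just a small part of it is carried over. A modest fall in the number is expected, possibly none beyond the scatter. The expected step is a 1.8-fold lower number from compound 1 to compound 4 (0.26 log units; within the scatter). For compound 4 the estimate is 3200 nM, with an expected range of 1000 nM to 9000 nM.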

Compound 4, half-maximal inhibitory concentration: 600 nM
The estimate for compound 4 lay 5.3-fold (0.73 log units) above the measured number, and the stated range ends above it.
By their numbers in this assay, from the lowest: compounds 4 and 3 (each within the scatter of the next); then compounds 1 and 2 (each within the scatter of the next).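

In this assay, fluoro in place of methoxy gives a 9.7-fold lower number from compound 1 to compound 4 (0.99 log units; beyond the scatter) on this evidence, with the rest of compound 1 unchanged. The aromatic carbon para to a large group is therefore a sensitive point in the series, which the earlier step, involving a different pair of groups, could not show. No measurement on hand accounts for the size of this step.

Going by these compounds, whether a chloro, an amine or a carboxylic acid at this position would track with fluoro or methoxy remains open. Also open, on these data alone, is whether fluoro gives a similar step on other aryl carbons.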